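This account rests on a few compounds, and the source may have more. Where it says the series, first, only, none or still open, it means among the compounds named here.

Of the compounds shown here, two have so far been measured in a functional assay on L1210 cells (Mus musculus) for antiproliferative activity; a lower number here means a less potent compound, a higher number a more potent compound, by a factor of ten per unit of this negative logarithm. Compound 1 `C=CCN(C)/N=N/c1ccc(NC(N)=O)cc1` gives 3.77 in this assay. Compound 2 `CN(C)/N=N/c1ccc(C(N)=O)cc1` gives 3.51 in this assay. Within the data shown here, of the two numbers, the one for compound 2 is the lower, but the gap to compound 1 lies within the usual scatter of repeated measurements, so the two cannot be told apart on these figures alone; they also differ from each other in two places, so no single step can be read between them.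

Compound 3 `C=CCN(C)/N=N/c1ccc(C(N)=O)cc1` has not yet been measured. It differs from compound 2 in one place: vinyl in place of hydrogen on a saturated chain carbon bound to an amine nitrogen. Cut one bond further out, the same difference reads as methyl to allyl, or dimethylamino to allyl(methyl)amino. Among the measured compounds shown here, nothing among the measured compounds isolates this change, so no step is available to anchor it. The expectation is therefore one of little movement: the step from compound 2 to compound 3 is estimated at a number 0.19 log units higher from compound 2 to compound 3 (within the scatter), not beyond the scatter. Compound 3 is accordingly expected to give 3.7 in this assay, in a range from 3.2 to 4.2.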

Compound 3, logarithm of the reciprocal of the active concentration, log(1/C) in the L1210 assay: 3.38
Compound 3: middle estimate off by 0.32 log units, on the high side, and the stated range covers the measured number.
By their numbers in the L1210 assay, from the lowest: compounds 3, 2 and 1 (each within the scatter of the next, the first and the last beyond it).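

Among these compounds, in the L1210 assay the vinyl in place of hydrogen on a saturated chain carbon bound to an amine nitrogen gives a number 0.13 log units lower from compound 2 to compound 3 (within the scatter), which leaves the two compounds indistinguishable, while carbamoyl in place of ureido on an aromatic carbon gives a number 0.39 log units lower from compound 1 to compound 3 (beyond the scatter), so the one step beyond the scatter in this small set lies at that aromatic carbon and not on the chain. In a physicochemical assay for lipophilicity, measured as octanol-water partition (a lower number here means a more polar compound, a higher number a more lipophilic compound), compound 2 gives 1.2 and compound 3 gives 2.09. Going from dimethylamino to allyl(methyl)amino thus makes compound 3 the more lipophilic of this pair, with no movement beyond the scatter in the L1210 assay: the measured partition coefficient of compound 2, 1.2, and of compound 3, 2.09, a number 0.89 log units higher (beyond the scatter)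

On these data alone, with a single step at this chain position, no general link between partition and antiproliferative activity can be drawn, and it remains open whether a longer saturated chain or a chain bearing a hydroxyl group on the amine nitrogen would behave as the allyl group does. Among the compounds shown here, the step from ureido to carbamoyl is also seen only with allyl(methyl)amino in place, so its size with dimethylamino remains unknown.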